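Sulfonamide oxadiazoles: methyl to chloro step

The compounds below may be only part of what the source reports. "The series", "measured", "known", "first", "only" and "open" are said of these compounds alone.

Measured so far in an assay on cells for inhibition of Amine oxidase [flavin-containing] A (Homo sapiens), read by fluorescence and spectrophotometry, using microsomes, with a stated time of 20 min; on this read-out lower numbers stand for stronger inhibition and higher numbers for weaker inhibition:

Compound 1 `NS(=O)(=O)c1cccc(-c2nnc(-c3ccc(F)cc3)o2)c1`: 34400 nM
Compound 2 `NS(=O)(=O)c1ccc(C(=O)NNC(=O)c2ccc(Cl)c(Cl)c2)cc1`: 13600 nM
Compound 3 `Cc1ccc(-c2nnc(-c3cccc(S(N)(=O)=O)c3)o2)cc1`: 61400 nM

Compound 3 gives the highest of the three numbers. Its nearest neighbour is compound 1, whose number is lower by an amount within the scatter, so the two cannot be ordered; compound 2 is furthest, with a number lower than that of compound 3 by a gap beyond the scatter. Going by the values given here, compound 2 is built on a different core, so no single-point step links it to compound 3.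

Compound 4 `NS(=O)(=O)c1cccc(-c2nnc(-c3ccc(Cl)cc3)o2)c1` is not yet measured. It differs from compound 3 in one place: chloro in place of methyl on an aromatic carbon. Among the compounds with values here, the only measured step at this position is a 1.8-fold higher number from compound 1 to compound 3 (0.25 log units; within the scatter), which exchanged fluoro for methyl and stayed within the scatter. Chloro is a second halogen at the same position, and fluoro and methyl behaved alike there, so no step beyond the scatter is expected for a 1.5-fold lower number from compound 3 to compound 4 (0.19 log units; within the scatter) in this assay.

Compound 4 is estimated at 40000 nM, within a range from 15000 nM to 100000 nM.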

Compound 4, half-maximal inhibitory concentration: > 100000 nM
Compound 4 was reported as a limit; the forecaster's own chance of this, stated with the estimate: 10%; middle value at least 2.5-fold (0.39 log units) from the limit.
By their numbers in this assay, from the lowest: compound 2; then compounds 1 and 3 (each within the scatter of the next). At a limit, above all of these: compound 4.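

In this assay compound 4 stands only as a limit, not as a number: the limit of > 100000 nM in this assay, at which 1 of the 4 values shown sits.

This gives the position on the aromatic ring, para to a large group, its first step beyond the scatter: an at least 2.9-fold higher number from compound 1 to compound 4 (0.46 log units; beyond the scatter), with chloro in place of fluoro, whereas the earlier exchange of fluoro for methyl gave only a 1.8-fold higher number from compound 1 to compound 3 (0.25 log units; within the scatter), so the position is not indifferent to every exchange and the two halogens do not behave alike there. On these data alone, the step with chloro in place of methyl is less firm, at an at least 1.6-fold higher number from compound 3 to compound 4 (0.21 log units; that floor lies within the scatter): its floor lies within the scatter, so compound 4 cannot yet be set apart from compound 3, and the true size of this step remains unknown.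

The compounds shown leave open how far compound 4 lies past the limit, and so whether chloro differs from methyl at all at this position. They also leave open whether bromo, methoxy, an amine or a carboxylic acid at the same place would give a lower number than fluoro or a number that again reaches the limit.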